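From 2-fluorophenyl to 1-benzothiophen-2-yl on a sulfonamide nitrogen

The compounds below may be only part of what the source reports. "The series", "measured", "known", "first", "only" and "open" are said of these compounds alone.

Of the compounds shown here, two sharing one core have been measured so far. In a physicochemical assay for lipophilicity, at pH 7.4 (on this read-out higher numbers stand for higher lipophilicity and lower numbers for lower lipophilicity), compound 1 `CC(C)CN(c1ccccc1F)S(=O)(=O)c1ccc2c(c1)C(O)CC(C1CCOCC1)O2` gives 3.39 as the higher of the two numbers. Compound 2 `O=S(=O)(Nc1ccccc1C(F)(F)F)c1ccc2c(c1)C(O)CC(C1CCOCC1)O2` gives 2.41 as its number, and that gap lies beyond the usual scatter of repeated measurements. These two compounds differ in more than one place, so their gap cannot be tied to any single group.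

The next compound is compound 3 `CC(C)CN(c1cc2ccccc2s1)S(=O)(=O)c1ccc2c(c1)C(O)CC(C1CCOCC1)O2`, which keeps everything in compound 1 except one group. Within the data shown here, it carries 1-benzothiophen-2-yl in place of 2-fluorophenyl on a sulfonamide nitrogen as its only change. Among the measured compounds shown here, no measured pair shows this swap, so the expectation rests on the structural change alone.

In this assay an upward step is expected, a number 0.71 log units higher from compound 1 to compound 3 (beyond the scatter) and larger than the usual scatter. For compound 3 the estimated value is 4.1 with an expected range from 3.6 to 4.6 in this measurement.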

Compound 3, distribution coefficient: 3.92
Compound 3: the middle estimate sits 0.18 log units above what was measured, and the stated range covers the measured number.
By their numbers in this assay, from the lowest: compound 2; then compound 1; then compound 3.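

Among these compounds, this is the first change that can be read at a single place: with everything else held, 1-benzothiophen-2-yl in place of 2-fluorophenyl on the sulfonamide nitrogen gives, in this assay, a number 0.53 log units higher from compound 1 to compound 3 (beyond the scatter). The gap between compound 1 and compound 2 could not be tied to one group, whereas this step shows that the group on this nitrogen alone can move the number by more than the usual scatter. Nothing available here gives a reason for the rise.

This one step removes the fluorine and brings in the sulfur and a second aromatic ring all at once, and the compounds shown do not separate these changes. Also open, as far as these compounds go, is how the number would respond to a plain phenyl or a pyridine ring on this nitrogen.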